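A para substituent swap on a short ketoamide chain

This account rests on a few compounds, and the source may have more. Where it says the series, first, only, none or still open, it means among the compounds named here.

Compound 1 `O=C(CCC(=O)c1ccc(F)cc1)NCCCO`: 300 mg/kg
Compound 2 `O=C(CCC(=O)c1ccc(Cl)cc1)NCCCO`: 300 mg/kg

In a functional assay on the whole organism (Central nervous system) for activation, with Mus musculus as the target (on this read-out higher numbers stand for an effect only at larger amounts of compound and lower numbers for an effect already at smaller amounts), compound 2 gives 300 mg/kg, level with compound 1 on the digits shown. Among the measured compounds shown here, the one step measured so far, no change at the digits printed from compound 1 to compound 2 (within the scatter), shows that swapping one halogen for another left the read-out unchanged. Compound 3 `COc1ccc(C(=O)CCC(=O)NCCCO)cc1` carries methoxy in place of chloro on an aromatic carbon. For the measured compounds named here, no measured step covers a methoxy group, so the only guide is that a change at this position did nothing before. Compound 3 is therefore expected to show no step beyond the scatter, no change at the digits printed from compound 2 to compound 3 (within the scatter), with an estimated 300 mg/kg and a range from 150 mg/kg to 600 mg/kg.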

Compound 3, dose for half-maximal effect: 150 mg/kg
Compound 3: middle estimate off by 2.0-fold (0.30 log units), on the high side; the range from low to high includes it.
By their numbers in this assay, from the lowest: compounds 3, 1 and 2 (each within the scatter of the next).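

Methoxy differs from a halogen in kind, with two heavy atoms and a hydrogen-bond acceptor, yet replacing chloro gives a 2.0-fold lower number from compound 2 to compound 3 (0.30 log units; within the scatter) and replacing fluoro gives a 2.0-fold lower number from compound 1 to compound 3 (0.30 log units; within the scatter). Compounds 1, 2 and 3 therefore cannot be told apart, so this position has accepted a group other than a halogen without a step beyond the scatter. Nothing available explains this result.

As far as these compounds go, whether an amine, a carboxylic acid or a longer chain at this position would give a clear step remains open. So does the effect of changes elsewhere on the shared core.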